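The compounds below may be only part of what the source reports. "The series", "measured", "known", "first", "only" and "open" are said of these compounds alone.

For the measured compounds named here, compound 1 `COc1cc(N2C(N)=C(C#N)C(c3cccc([N+](=O)[O-])c3)C3=C2CC(C)(C)CC3=O)cc(OC)c1OC` has the lowest number of the two compounds measured so far: in a functional assay on Ehrlich cells (Mus musculus) for cytotoxicity, tested at 50 ug/mL (on this read-out higher numbers stand for a stronger effect at the one concentration tested and lower numbers for a weaker effect), compound 1 gives 30%, while compound 2 `COc1cc(N2C(N)=C(C#N)C(c3ccc([N+](=O)[O-])cc3)C3=C2CC(C)(C)CC3=O)cc(OC)c1OC` gives 70%. Going by the values given here, the one step known, a number 40 percentage points higher from compound 1 to compound 2 (beyond the scatter), shows that exchanging the aryl group on the saturated ring carbon can move the read-out widely. Among the compounds with values here, compound 3 `COc1cc(N2C(N)=C(C#N)C(c3c(OC)ccc4ccccc34)C3=C2CC(C)(C)CC3=O)cc(OC)c1OC` differs from compound 1 by 2-methoxynaphthalen-1-yl in place of 3-nitrophenyl on a saturated ring carbon; no measured step covers this exchange, so its direction is open. Compound 3 is therefore expected to give about 45%, within 15% to 80%, an estimated step of a number 15 percentage points higher from compound 1 to compound 3 (beyond the scatter) of uncertain sign.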

Compound 3, a percentage reported as activity, at one concentration (the size of the read-out at that concentration, not a potency): 10%
Compound 3: middle estimate off by 35 percentage points, on the high side; measured number below the stated range.
By their numbers in this assay, from the lowest: compound 3; then compound 1; then compound 2.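

In this assay, 2-methoxynaphthalen-1-yl on the saturated ring carbon falls short of both nitrophenyl groups (a number 20 percentage points lower from compound 1 to compound 3 (beyond the scatter); a number 60 percentage points lower from compound 2 to compound 3 (beyond the scatter)). This position therefore tolerates more than the placing of one nitro group can show: an aryl group with two aromatic rings and no nitro group gives the lowest number of the three compounds. Nothing available accounts for this fall.

The compounds shown leave open whether the fall follows the fused second ring or the methoxy group. Naphthalen-1-yl without methoxy, or 2-methoxyphenyl, would separate the two.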